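This account rests on a few compounds, and the source may have more. Where it says the series, first, only, none or still open, it means among the compounds named here.

Measured so far:
compound 1 `O=C(CSc1nc(Nc2ccccc2)c2ccccc2n1)Nc1cccc(F)c1` — 15600 nM
compound 2 `O=C(CSc1nc(Nc2ccccc2)c2ccccc2n1)Nc1ccc(Cl)c(Cl)c1` — 12100 nM
compound 3 `C=CC(=O)Nc1cccc(NC(=O)CSc2nc(Nc3ccccc3C)c3ccccc3n2)c1` — 23200 nM

In a functional assay on PC-3 cells (Homo sapiens) for inhibition, read by MTT assay, with a stated time of 72 h (on this read-out lower numbers stand for stronger inhibition and higher numbers for weaker inhibition), compound 3 gives the highest of the three numbers, but its gap to compound 1 and to compound 2 is within the scatter, so no order among the three is claimed. Compound 4 `C=CC(=O)Nc1cccc(NC(=O)CSc2nc(Nc3ccc(F)cc3)c3ccccc3n2)c1` differs from compound 3 by 4-fluorophenyl in place of 2-methylphenyl on a nitrogen on an aromatic ring. Going by the values given here, the only measured step, a 1.3-fold lower number from compound 1 to compound 2 (0.11 log units; within the scatter), concerns the aryl on the amide-type nitrogen, not the aryl on a nitrogen on an aromatic ring changed here, and it stayed within the scatter; it bears on the present change only in showing that an aryl swap has so far moved nothing beyond the scatter. For compound 4 the step of a 1.2-fold lower number from compound 3 to compound 4 (0.06 log units; within the scatter) is therefore expected to stay within the scatter. Compound 4 is estimated at 20000 nM, range 8000 nM to 50000 nM.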

Compound 4, half-maximal inhibitory concentration: 8240 nM
Estimate against measurement, compound 4: 2.4-fold (0.39 log units) above; low and high end bracket the measured number.
By their numbers in this assay, from the lowest: compounds 4, 2, 1 and 3 (each within the scatter of the next, the first and the last beyond it).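

In this assay, going by these compounds alone, the aryl on a nitrogen on an aromatic ring gives the first step beyond the scatter: a 2.8-fold lower number from compound 3 to compound 4 (0.45 log units; beyond the scatter), with 4-fluorophenyl in place of 2-methylphenyl. The size is modest, but this position responds, whereas the aryl swap on the amide-type nitrogen stayed within the scatter. No measured evidence bears on the reason for this step.

The pair does not separate the change of substituent from its place on the phenyl. Also open, as far as these compounds go, is how 4-methylphenyl, 2-fluorophenyl or cyclohexyl would read on this nitrogen.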